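Side-chain swap on compound 3, from piperidine to pyrrolidine

This account rests on a few compounds, and the source may have more. Where it says the series, first, only, none or still open, it means among the compounds named here.

Measured in a functional assay on SK-BR-3 cells (Homo sapiens) for antiproliferative activity; on this read-out higher numbers stand for weaker inhibition and lower numbers for stronger inhibition:
- compound 1 `CC(=O)Oc1ccc(C(=O)Nc2cc3ccc(OCCC4CCCCN4)c(C)c3oc2=O)cc1CC=C(C)C`: 640 nM
- compound 2 `CC(=O)Oc1ccc(C(=O)Nc2cc3ccc(OCC4CCCNC4)c(C)c3oc2=O)cc1CC=C(C)C`: 620 nM
- compound 3 `CC(C)=CCc1cc(C(=O)Nc2cc3ccc(OCC4CCCNC4)c(C)c3oc2=O)ccc1O`: 600 nM

In this assay compound 3 gives 600 nM, which cannot be separated from the other two values given the scatter. Compound 4 `CC(C)=CCc1cc(C(=O)Nc2cc3ccc(OCCCN4CCCC4)c(C)c3oc2=O)ccc1O` changes the side chain of compound 3: 2-(pyrrolidin-1-yl)ethyl in place of piperidin-3-yl on a saturated chain carbon bound to an oxygen on an aromatic ring. The nearest evidence is a change at the same place, a 1.0-fold lower number from compound 1 to compound 2 (0.01 log units; within the scatter). The other measured change lies elsewhere in the molecule, a 1.0-fold lower number from compound 2 to compound 3 (0.01 log units; within the scatter), and bears on this swap only indirectly. Among the compounds with values here, no measured compound carries a pyrrolidine ring, so the evidence is thin. No shift beyond the scatter is expected, and the expected step is a 1.1-fold lower number from compound 3 to compound 4 (0.04 log units; within the scatter). For compound 4 the estimated value is 550 nM, with an expected range of 220 nM to 1400 nM.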

Compound 4, half-maximal inhibitory concentration: 720 nM
For compound 4 the middle estimate is 1.3-fold (0.12 log units) below the measured one, and the stated range covers the measured number.
By their numbers in this assay, from the lowest: compounds 3, 2, 1 and 4 (each within the scatter of the next).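

The swap at this place gives a 1.2-fold higher number from compound 3 to compound 4 (0.08 log units; within the scatter) in this assay. Compound 4 thus shows that a five-membered non-aromatic ring can stand here in place of a six-membered one, with the hydrogen-bond donor of piperidin-3-yl gone, without a shift beyond the scatter. No measurement at hand bears on why the step stays this small.

From the compounds shown here alone, whether a morpholine or a carboxylic acid on this chain would move the number beyond the scatter remains open. So does whether the swap would read the same with an acetyl group on the aromatic oxygen.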